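A few compounds are considered here, and "the series" means these few. Any claim that something is new, unique, unknown or untested is made for them only; others in the source may bear on it.

Measured compounds:

Compound 1, `COc1ccc(/C=C/C(=O)c2cc(NC(C)=O)ccc2O)cc1`, gives 38700 nM.
Compound 2, `CC(=O)Nc1ccc(O)c(C(=O)/C=C/c2ccc(F)cc2)c1`, gives 41100 nM.
Compound 3, `COc1ccc(-c2cc(=O)c3cc(N)ccc3o2)cc1`, gives 241000 nM.

The three measured compounds were tested in an ADME assay on MT4 cells (Homo sapiens) for cytotoxicity, read by MTT assay, with a stated time of 4 days; a lower number here means that less compound is tolerated, a higher number that more compound is tolerated. Compound 1 and compound 2 share one core and differ in a single place: fluoro in place of methoxy on an aromatic carbon. The step that this change made is a 1.1-fold higher number from compound 1 to compound 2 (0.03 log units; within the scatter), so compound 1 and compound 2 are not separated by more than the usual scatter in this assay. Compound 3 has a different core; the difference between the two cores is not broken down here. Compound 3 gives the highest number of the three, and its gap to compound 2 and to compound 1 lies beyond the scatter.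

Compound 4, `Nc1ccc2oc(-c3ccc(F)cc3)cc(=O)c2c1`, has not yet been measured in this assay. It differs from compound 3 in one place: fluoro in place of methoxy on an aromatic carbon. Among the compounds with values here, this is the same change as the one that separates compound 1 from compound 2, and the place lines are identical word for word. Since that earlier change moved the number by only a 1.1-fold higher number from compound 1 to compound 2 (0.03 log units; within the scatter), compound 4 is expected to stand close to compound 3, with an estimated step of a 1.0-fold higher number from compound 3 to compound 4 (0.02 log units; within the scatter). This expectation rests on a single precedent on another core, so its uncertainty is wider than the scatter alone. Compound 4 is estimated at 250000 nM, between 120000 nM and 500000 nM.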

Compound 4, half-maximal cytotoxic concentration: 264000 nM
The estimate for compound 4 lay 1.1-fold (0.02 log units) below the measured number, within the range that was stated.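

In this assay, putting fluoro in place of methoxy on an aromatic carbon gave a 1.1-fold higher number from compound 3 to compound 4 (0.04 log units; within the scatter), so compound 4 is not separated from compound 3 by more than the usual scatter. The change therefore left the number as unmoved on the core of compound 3 as it had on the core of compound 1, and the two steps agree with each other: the same change on two cores in this assay, a 1.1-fold higher number (0.03 log units; within the scatter) from compound 1 to compound 2 and a 1.1-fold higher number (0.04 log units; within the scatter) from compound 3 to compound 4, 1.0-fold (0.01 log units) apart, within the scatter of two such steps

This shows that, for these two pairs, the swap carried over from one core to the other without a step beyond the scatter, but it does not show that the same would hold on any further core or in any other assay, and steps this small cannot say whether the change has any real effect of its own on either core.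

The compounds shown leave open whether another group on that aromatic carbon, such as a hydroxyl, an amine or a carboxylic acid, would also stay within the scatter. They also leave open which part of the difference between the two cores goes with the higher numbers of compound 3 and compound 4, since no pair shown differs in one place across the two cores.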